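A few compounds are considered here, and "the series" means these few. Any claim that something is new, unique, unknown or untested is made for them only; others in the source may bear on it.

Compound 2 `Cc1c(COc2cc(N)nc3[nH]nnc23)cccc1-c1cccc(F)c1` gives 23 nM in an assay for inhibition of Myeloperoxidase (Homo sapiens), read by Amplex Red, with stated times of 10 min and 15 min; on this read-out lower numbers stand for stronger inhibition and higher numbers for weaker inhibition. Compound 1 `Cn1ccc(-c2cccc(COc3cc(N)nc4[nH]nnc34)c2)n1` gives 21 nM in this assay; the two numbers lie within the usual scatter of each other, so neither stands apart. Compound 3 `Cc1c(COc2cc(N)nc3[nH]nnc23)cccc1-c1ccn(C)n1` has not yet been measured in this assay. It differs from compound 2 by 1-methyl-1H-pyrazol-3-yl in place of 3-fluorophenyl on an aromatic carbon. Within the data shown here, no measured pair shows this exchange on its own, but compound 1 already carries the entering group and gives 21 nM, close to compound 2, so no step beyond the scatter is expected. The estimated value of compound 3 in this assay is 20 nM, with a range from 8 nM to 50 nM. This corresponds to an expected step of a 1.2-fold lower number from compound 2 to compound 3 (0.06 log units; within the scatter).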

Compound 3, half-maximal inhibitory concentration: 26 nM
The estimate for compound 3 lay 1.3-fold (0.11 log units) below the measured number; measured number inside the range.
By their numbers in this assay, from the lowest: compounds 1, 2 and 3 (each within the scatter of the next).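

In this assay, 1-methyl-1H-pyrazol-3-yl in place of 3-fluorophenyl, ortho to a methyl group, gives a 1.1-fold higher number from compound 2 to compound 3 (0.05 log units; within the scatter) and shows that this position accepts either ring without a step beyond the scatter. Methyl in place of hydrogen on an aromatic carbon gives a 1.2-fold higher number from compound 1 to compound 3 (0.09 log units; within the scatter) and likewise leaves the number within the scatter. Nothing available explains why either change leaves the number so little altered.

As far as these compounds go, whether an amine or a carboxylic acid on this aromatic carbon would keep the number within this range remains open. So does the effect of a longer chain there.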